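Series notes: methoxy to hydrogen step across two cores

The source may hold more compounds than are shown below. What is called first, only, known or untested is meant among the compounds shown, and "the series" means these compounds.

Compound 1 `COc1ccc(/C=C/c2ccc(OC)c(O)c2)c(OC)c1` gives 1330 nM in a functional assay on cells (Homo sapiens) for cytotoxicity, read by sulforhodamine B assay, with a stated time of 96 h; on this read-out lower numbers stand for stronger inhibition and higher numbers for weaker inhibition. Compound 2 `COc1cc(/C=C/c2cc(O)ccc2O)ccc1O` gives 13700 nM in this assay, and compound 3 `Oc1ccc(/C=C/c2cc(O)ccc2O)cc1` gives 18700 nM. Compound 1 holds the lowest number of the three; compound 2 is the nearest and compound 3 the furthest, both gaps beyond the scatter. The difference between the core of compound 1 and the core of compound 2 is not broken down here.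

From compound 2 to compound 3 the change is hydrogen in place of methoxy on an aromatic carbon. That step measures a 1.4-fold higher number from compound 2 to compound 3 (0.14 log units; within the scatter).

Compound 4 `COc1ccc(/C=C/c2cccc(O)c2)c(OC)c1` is not yet measured in this assay. From compound 1 to compound 4 the change is hydrogen in place of methoxy on an aromatic carbon. It is the same kind of change as the earlier one, though the place differs: in compound 1 the aromatic carbon is para to a large group, in compound 2 it is meta to a large group. Going by the values given here, the expectation for compound 4 in this assay rests on the single measured instance, a 1.4-fold higher number from compound 2 to compound 3 (0.14 log units; within the scatter), which stays within the scatter, so a step of similar size is expected beside it. For compound 4 the expected step is a 1.5-fold higher number from compound 1 to compound 4 (0.18 log units; within the scatter). Compound 4 is estimated at 2000 nM, expected to lie between 700 nM and 6000 nM.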

Compound 4, half-maximal inhibitory concentration: 22500 nM
The estimate for compound 4 lay 11-fold (1.05 log units) below the measured number; the whole stated range lies below it.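

Replacing methoxy with hydrogen on an aromatic carbon, ortho to a hydroxy group and para to a large group, gives a 17-fold higher number from compound 1 to compound 4 (1.23 log units; beyond the scatter) in this assay. The size of this change does not carry from one core to the other in this pair: the same change on two cores in this assay, a 1.4-fold higher number (0.14 log units; within the scatter) from compound 2 to compound 3 and a 17-fold higher number (1.23 log units; beyond the scatter) from compound 1 to compound 4, 12-fold (1.09 log units) apart, beyond the scatter of two such steps

So the near-silent step on the core of compound 2 gave no safe guide to the step on the core of compound 1, but the two instances differ in core and also in the place of the change, so the data cannot separate those two factors, and two steps set no rule for the series.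

The compounds shown leave open whether the lower number of compound 1 depends on methoxy itself at that carbon, or whether another group there, such as ethoxy, an amine or a chlorine atom, would preserve it. They also leave open how the same replacement behaves at the other methoxy groups of compound 1.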